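The source may report more compounds than this note shows. Statements on the series, on what has been measured and on what is new or still open speak of the compounds shown alone.

Measured so far in a functional assay on MCF7 cells (Homo sapiens) for inhibition, read by trypan blue exclusion, with a stated time of 72 h; a lower number here means a stronger inhibitor of growth, a higher number a weaker inhibitor of growth:

compound 1 `CC/C(=C(\c1ccccc1)c1ccc(NC(=O)C(C)C)cc1)c1ccc(OCc2ccccc2)cc1` gives > 30000 nM.
compound 2 `CC/C(=C(/c1ccc(NC(=O)C(C)C)cc1)c1ccc(OC)cc1)c1ccc(OCc2ccccc2)cc1` gives 29000 nM.
compound 3 `CC/C(=C(/c1ccccc1)c1ccc(NC(=O)C(C)C)cc1)c1ccccc1` gives > 30000 nM.

The value of compound 1 is a limit of the assay, not a number. The value of compound 3 is likewise a limit of the assay. Only compound 2 gives a number, and that number sits close to the limit of this assay.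

For the measured compounds named here, the one change made between measured compounds is methoxy in place of hydrogen on an aromatic carbon. Its step is an at least 1.0-fold lower number from compound 1 to compound 2 (0.01 log units; that floor lies within the scatter); since (the limit of > 30000 nM in this assay, at which 2 of the 3 values shown sit), this step can only be read as a floor, and a floor that lies within the scatter.

Compound 4 `CC/C(=C(\c1ccc(NC(=O)C(C)C)cc1)c1ccc(OC)cc1)c1ccccc1` is not yet measured. It differs from compound 3 by methoxy in place of hydrogen on an aromatic carbon, which is the same change as from compound 1 to compound 2, set on the same kind of place. How the core of compound 3 differs from the core of compound 1 is not broken down here.

For compound 4 the expected step is a number no higher from compound 3 to compound 4 (the limit leaves the size open), set beside an at least 1.0-fold lower number from compound 1 to compound 2 (0.01 log units; that floor lies within the scatter) and resting on that earlier step. The estimate for compound 4 is 30000 nM, expected between 15000 nM and 60000 nM, with a fair chance that this assay again reports only a limit.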

Compound 4, concentration for 50% growth inhibition: 27900 nM
For compound 4 the middle estimate is 1.1-fold (0.03 log units) above the measured one; low and high end bracket the measured number.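

In this assay, methoxy in place of hydrogen on an aromatic carbon, read here as phenyl to 4-methoxyphenyl, gives an at least 1.0-fold lower number from compound 3 to compound 4 (0.03 log units; that floor lies within the scatter), which is a floor and not a measured size. On both cores the change leaves a floor within the scatter, so the two readings agree only as far as they can be read, and this does not show that the same effect carries from one core to the other: the same change on two cores in this assay, an at least 1.0-fold lower number (0.01 log units; that floor lies within the scatter) from compound 1 to compound 2 and an at least 1.0-fold lower number (0.03 log units; that floor lies within the scatter) from compound 3 to compound 4; the limit leaves it open whether they differ. From the compounds shown here alone, the true size of the change stays unknown on either core, and the series sits at the edge of what this read-out can resolve: the limit of > 30000 nM in this assay, at which 2 of the 4 values shown sit.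

Still open, going by these compounds, is whether any group at this place gives a number clearly apart from the limit. A hydroxyl, an amine or a longer alkoxy chain in place of methoxy would test this in this assay, as would a carboxylic acid on the same aromatic carbon.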